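Swapping a Naphthol for a Quinolinone on the Urea

The source may report more compounds than this note shows. Statements on the series, on what has been measured and on what is new or still open speak of the compounds shown alone.

Measured compounds:
Compound 1, `CN(C)C1(Cc2ccccc2)CCN(c2cc(C(F)(F)F)ccc2CNC(=O)NCc2ccc(NS(C)(=O)=O)c(F)c2)CC1`, gives 266 nM in an assay on CHO cells for displacement of a labelled ligand from transient receptor potential cation channel subfamily V member 1 (Homo sapiens), read by scintillation counting, with a stated time of 60 min; a higher number here means a weaker inhibitor, a lower number a stronger inhibitor.
Compound 2, `CN(C)C1(Cc2ccccc2)CCN(c2cc(C(F)(F)F)ccc2CNC(=O)Nc2ccc(CNS(N)(=O)=O)c(F)c2)CC1`, gives 15.3 nM in this assay.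
Compound 3, `CN(C)C1(Cc2ccccc2)CCN(c2cc(C(F)(F)F)ccc2CNC(=O)Nc2cccc3ccc(O)cc23)CC1`, gives 0.46 nM in this assay.

All three share the same core and differ only in the group attached to the far end of the urea. Compound 3 carries the lowest number of the three and therefore binds most tightly: its value sits well beyond the scatter from compound 2 and even further from compound 1, so its place at the strong end is secure.

Compound 4, `CN(C)C1(Cc2ccccc2)CCN(c2cc(C(F)(F)F)ccc2CNC(=O)Nc2cccc3[nH]c(=O)ccc23)CC1`, is the next step from compound 3. The change is a group of 11 heavy atoms (9 carbon, 1 nitrogen, 1 oxygen; one six-membered aromatic ring of carbon only, one six-membered aromatic ring with 1 hetero atom) in place of a group of 11 heavy atoms (10 carbon, 1 oxygen; 2 six-membered aromatic rings of carbon only), on an amide-type nitrogen. In other words, a 7-hydroxynaphthalen-1-yl group is exchanged for a fused ring system of the same size in which one ring now carries a nitrogen and a carbonyl-type oxygen. The tally of hydrogen-bond donors and acceptors stays the same, as the comparison shows, and the overall shape of the two groups is closely matched.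

For the measured compounds named here, no measured pair shows what such an exchange does here, so the expectation rests on the likeness of the two groups. A small shift toward a weaker number, at most a little beyond the scatter, is expected for the step of a 3.3-fold higher number from compound 3 to compound 4 (0.51 log units; beyond the scatter). Compound 4 is therefore estimated at 1.5 nM in this assay, with a likely range from 0.3 nM to 8 nM.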

Compound 4, inhibition constant: 1.67 nM
Estimate against measurement, compound 4: 1.1-fold (0.05 log units) below; measured number inside the range.
By their numbers in this assay, from the lowest: compound 3; then compound 4; then compound 2; then compound 1.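

For the compounds shown here, the step on the amide-type nitrogen is the first exchange here that can be read as a single change. Replacing the 7-hydroxynaphthalen-1-yl group with a fused ring system holding the same number of heavy atoms, hydrogen-bond donors and hydrogen-bond acceptors gives a 3.6-fold higher number from compound 3 to compound 4 (0.56 log units; beyond the scatter) in this assay. The step is modest but beyond the usual scatter, so this position distinguishes between two closely matched groups, even though compound 4 still gives a low number at 1.67 nM. No measurement shown here explains the shift, so it cannot be assigned to either the ring nitrogen or the carbonyl oxygen.

The ring nitrogen, the carbonyl and the loss of the hydroxyl arrive together in this exchange, leaving the contribution of each one open. From the compounds shown here alone, a plain naphthalen-1-yl group, or a methoxy group in place of the hydroxyl on the naphthalene, would help to separate these contributions, and it also remains open whether the same exchange would give a similar step on a different core.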